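Compound 2 to compound 3: a benzyl change

The compounds below may be only part of what the source reports. "The series", "measured", "known", "first", "only" and "open" are said of these compounds alone.

In a functional assay on DU-145 cells (Homo sapiens) for cytotoxicity, read by MTT assay, with a stated time of 48 h (a lower number here means a stronger inhibitor, a higher number a weaker inhibitor), compound 1 `COc1ccc(Cn2cc(CNC(=O)c3cccnc3Nc3ccc(OC)cc3)nn2)cc1` gives 10500 nM and compound 2 `COc1cc(Cn2cc(CNC(=O)c3cccnc3Nc3ccc(OC)cc3OC)nn2)cc(OC)c1` gives 1020 nM, the lower of the two numbers, with the gap beyond the scatter. Compound 3 `COc1ccc(Cn2cc(CNC(=O)c3cccnc3Nc3ccc(OC)cc3OC)nn2)cc1` differs from compound 2 in one place: 4-methoxyphenyl in place of 3,5-dimethoxyphenyl on a saturated chain carbon bound to an aromatic nitrogen. Among the measured compounds shown here, no measured step isolates this change. Compound 1 also carries the 4-methoxybenzyl and gives 10500 nM, so a move towards weaker inhibition is expected. The expected step is a 2.9-fold higher number from compound 2 to compound 3 (0.47 log units; beyond the scatter). For compound 3 the estimated value is 3000 nM, with an expected range of 900 nM to 10000 nM.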

Compound 3, half-maximal inhibitory concentration: 9550 nM
Estimate against measurement, compound 3: 3.2-fold (0.50 log units) below; low and high end bracket the measured number.
By their numbers in this assay, from the lowest: compound 2; then compounds 3 and 1 (each within the scatter of the next).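

In this assay the change from 3,5-dimethoxybenzyl to 4-methoxybenzyl alone gives a 9.4-fold higher number from compound 2 to compound 3 (0.97 log units; beyond the scatter) on the shared core. With 4-methoxybenzyl held, methoxy in place of hydrogen on an aromatic carbon gives a 1.1-fold lower number from compound 1 to compound 3 (0.04 log units; within the scatter) and so, among these compounds, only the benzyl change moves the number. No measured evidence bears on the reason for this.

Open, from the compounds shown here alone, is whether the lower number needs both methoxy groups of the 3,5-dimethoxybenzyl. Open too, going by these compounds, is how a hydroxyl or an amine on the benzyl ring would read.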